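The source may report more compounds than this note shows. Statements on the series, on what has been measured and on what is new or still open speak of the compounds shown alone.

Measured so far:
compound 1 `COc1cc(C)c(S(=O)(=O)N(C)CCOCC(=O)N2CCC(C(C)(C)CN(C)C)CC2)c(C)c1` gives 7.5 in a functional assay on Umbilical vein for antagonist activity at B1 bradykinin receptor (Homo sapiens), using Schild analysis, with a stated time of 30 min; on this read-out lower numbers stand for lower potency and higher numbers for higher potency (the scale is a negative logarithm)
compound 2 `Cc1c(Cl)ccc(S(=O)(=O)N(C)CCC(=O)N(C)Cc2ccc(C3=NCCN3)cc2)c1Cl` gives 8.5 in this assay

Compound 1 holds the lower of the two numbers in this assay; compound 2 stands higher by a gap beyond the usual scatter. The two compounds differ in several places at once, so no single change can be read from that gap.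

Compound 3 `COc1cc(C)c(S(=O)(=O)N(C)CCOCC(=O)N2CCC(C3CCN(C(C)C)CC3)CC2)c(C)c1` has not been measured. It differs from compound 1 in one place: 1-isopropylpiperidin-4-yl in place of 1-((dimethylamino)methyl)-1-methylethyl on a saturated ring carbon. For the measured compounds named here, no measured pair covers a change of this kind, so nothing anchors its size. What is counted is modest: the leaving and entering groups each carry one hydrogen-bond acceptor, no donor and no net charge, and the entering group brings one six-membered non-aromatic ring with one hetero atom. The expected step in this assay, a number 0.20 log units higher from compound 1 to compound 3 (within the scatter), is small and, if anything, upward, not clearly beyond the scatter. Compound 3 is accordingly expected to give 7.7, with a likely range from 7.1 to 8.3.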

Compound 3, negative logarithm of the antagonist equilibrium constant: 9.3
Compound 3: the middle estimate sits 1.60 log units below what was measured, outside the stated range (above it).
By their numbers in this assay, from the lowest: compound 1; then compound 2; then compound 3.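

At this saturated ring carbon, 1-isopropylpiperidin-4-yl in place of 1-((dimethylamino)methyl)-1-methylethyl gives a number 1.80 log units higher from compound 1 to compound 3 (beyond the scatter) in this assay, so the position responds strongly to the group it carries. The leaving and entering groups match in hydrogen-bond donors, hydrogen-bond acceptors and net charge, so these counts do not separate them; the counted differences are the six-membered non-aromatic ring and the higher heavy-atom count of the entering group. Nothing measured here gives a reason for the size of this step.

For the compounds shown here, only this one pair covers the position, and it leaves open whether the ring or the isopropyl carries the step. A methyl or a cyclopropyl on the nitrogen of the entering ring would bear on that question, as would an open-chain tertiary amine in place of the ring.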